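The source may hold more compounds than are shown below. What is called first, only, known or untested is meant among the compounds shown, and "the series" means these compounds.

Measured so far in a functional assay on A549 cells (Homo sapiens) for antiproliferative activity, read by MTT assay, with a stated time of 72 h; a lower number here means a stronger inhibitor, a higher number a weaker inhibitor:
Compound 1, `O=C1O/C(=C\Cn2cc(-c3ccc(Br)cc3)nn2)C(OCc2ccccc2)=C1OCc1ccccc1`, gives > 100000 nM, which is a limit of the assay and not a number.
Compound 2, `O=C1O[C@H]([C@@H](O)Cn2cc(-c3cc(C(F)(F)F)cc(C(F)(F)F)c3)nn2)C(OCc2ccccc2)=C1OCc1ccccc1`, gives 28900 nM.
Compound 3, `CCCCCCCCCCc1cn(C[C@H](O)[C@H]2OC(=O)C(OCc3ccccc3)=C2OCc2ccccc2)nn1`, gives 6750 nM.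

Of the two numbers, compound 3 holds the lower one, and its gap to compound 2 lies beyond the scatter. Compound 4, `COc1ccc(-c2cn(C[C@H](O)[C@H]3OC(=O)C(OCc4ccccc4)=C3OCc3ccccc3)nn2)cc1`, is not yet measured and differs from compound 3 in one place: 4-methoxyphenyl in place of decyl on an aromatic carbon. Compound 2, which also carries an aryl group on that ring, gives the higher number of the two. On that showing, compound 4 is expected to be a weaker inhibitor than compound 3, by a step beyond the scatter. In this assay compound 4 is estimated at 30000 nM, within 10000 nM to 100000 nM. That estimate means an expected step of a 4.4-fold higher number from compound 3 to compound 4 (0.65 log units; beyond the scatter).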

Compound 4, half-maximal inhibitory concentration: 28300 nM
The estimate for compound 4 lay 1.1-fold (0.03 log units) above the measured number; low and high end bracket the measured number.
By their numbers in this assay, from the lowest: compound 3; then compounds 4 and 2 (each within the scatter of the next). At a limit, above all of these: compound 1.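

In this assay, among the compounds shown here, the exchange on the aromatic carbon of the five-membered aromatic ring gives the first direct reading at this place: 4-methoxyphenyl in place of decyl brings a 4.2-fold higher number from compound 3 to compound 4 (0.62 log units; beyond the scatter). With an aryl group at this place, compound 4 gives 28300 nM and compound 2 gives 28900 nM, values within the scatter of each other. Compound 4 also gives a true number rather than a limit: the limit of > 100000 nM in this assay, at which 1 of the 4 values shown sits.

The step changes chain and ring together, so it does not separate the loss of decyl from the arrival of the aryl ring. A shorter chain such as hexyl, or an amine on the phenyl ring, would leave that question open no longer.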